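Toward Compound 4: A Morpholin-3-yl Replacement in This Series

The source may report more compounds than this note shows. Statements on the series, on what has been measured and on what is new or still open speak of the compounds shown alone.

Among the measured compounds shown here, in a functional assay on CHO cells for inhibition of Gonadotropin-releasing hormone receptor (Homo sapiens) (a higher number here means a weaker inhibitor, a lower number a stronger inhibitor), compound 1 `Cc1cc(-c2c(O)nc3cc(Cl)c(C(=O)Nc4cnsn4)cc3c2OCCC2CC3CCN2CC3)cc(C)c1C` gives 5.8 nM, the highest of the three numbers measured so far. Compound 2 `Cc1cc(-c2c(O)nc3cc(Cl)c(C(=O)Nc4ccncn4)cc3c2OCC[C@@H]2CCCCN2)cc(C)c1C` gives 2.2 nM, and compound 3 `Cc1cc(-c2c(O)nc3cc(Cl)c(C(=O)Nc4ccncn4)cc3c2OCC[C@@H]2CCCN2)cc(C)c1C` gives 2.2 nM; each of these stands below compound 1 by a gap that is beyond the scatter, while the two of them lie within the scatter of each other.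

Compound 4 `Cc1cc(-c2c(O)nc3cc(Cl)c(C(=O)Nc4cnsn4)cc3c2OCCC2COCCN2)cc(C)c1C` has not yet been measured. It differs from compound 1 by a group of 6 heavy atoms (4 carbon, 1 nitrogen, 1 oxygen; one six-membered non-aromatic ring with 2 hetero atoms) in place of a group of 8 heavy atoms (7 carbon, 1 nitrogen; 2 six-membered non-aromatic rings with 1 hetero atom each), on a saturated chain carbon, two bonds along the chain from an oxygen on an aromatic ring. For the measured compounds named here, only one measured step in this set touches the same position: no change at the digits printed from compound 2 to compound 3 (within the scatter), in which a pyrrolidin-2-yl took the place of a piperidin-2-yl on a saturated chain carbon, two bonds along the chain from an oxygen on an aromatic ring, and the number did not move beyond the scatter. Going by the values given here, that step exchanged one saturated nitrogen ring for another of a different size; the change to compound 4 also swaps one saturated ring group for another, though the entering group brings an oxygen and a hydrogen-bond donor that no measured compound here carries.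

On this evidence the step from compound 1 to compound 4 is expected to be small, a 1.2-fold higher number from compound 1 to compound 4 (0.08 log units; within the scatter), with no strong call on direction. Compound 4 is therefore estimated at 7 nM in this assay, with a range from 2.5 nM to 20 nM.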

Compound 4, half-maximal inhibitory concentration: 32 nM
The estimate for compound 4 lay 4.6-fold (0.66 log units) below the measured number; measured number outside the range, above it.
By their numbers in this assay, from the lowest: compounds 2 and 3 (each within the scatter of the next); then compound 1; then compound 4.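

In this assay the saturated chain carbon, two bonds along the chain from an oxygen on an aromatic ring, proves sensitive to the group it carries: morpholin-3-yl in place of the two-ring group gives a 5.5-fold higher number from compound 1 to compound 4 (0.74 log units; beyond the scatter). Among the compounds shown here, the earlier step at this place, no change at the digits printed from compound 2 to compound 3 (within the scatter), had exchanged only one saturated nitrogen ring for another, so the tolerance seen there does not carry over to this change on the core of compound 1. Nothing available here speaks to the reason for the rise in the number.

The change to compound 4 alters the ring count, the group size, the ring oxygen and the hydrogen-bond donor count together, so the compounds shown cannot assign the rise to any one of these. A piperidin-2-yl on the core of compound 1 would separate the loss of the second ring from the entry of the oxygen, and a thiomorpholin-3-yl or a piperazin-2-yl would show whether the rise is particular to the ring oxygen of morpholin-3-yl.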